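This account rests on a few compounds, and the source may have more. Where it says the series, first, only, none or still open, it means among the compounds named here.

Measured compounds:
compound 1 `C=CC(=O)Nc1cccc(NC(=O)CSc2nc(Nc3ccccc3Br)c3ccccc3n2)c1`: 17100 nM
compound 2 `C=CC(=O)Nc1cccc(NC(=O)CSc2nc(Nc3cccc(OC)c3)c3ccccc3n2)c1`: 34900 nM

In a functional assay on PC-3 cells (Homo sapiens) for inhibition, read by MTT assay, with a stated time of 72 h (a lower number here means a stronger inhibitor, a higher number a weaker inhibitor), compound 2 gives 34900 nM, the higher of the two numbers, with compound 1 as its nearest neighbour at 17100 nM. Going by the values given here, the only measured step, a 2.0-fold higher number from compound 1 to compound 2 (0.31 log units; beyond the scatter), is a modest one beyond the scatter. Compound 3 `C=CC(=O)Nc1cccc(NC(=O)CSc2nc(Nc3ccc(CC)cc3)c3ccccc3n2)c1` has not yet been measured; it differs from compound 2 by 4-ethylphenyl in place of 3-methoxyphenyl on a nitrogen on an aromatic ring. Among the compounds with values here, no measured step exchanges 3-methoxyphenyl for 4-ethylphenyl, so nothing bears directly on this change. Within the data shown here, the one related step, a 2.0-fold higher number from compound 1 to compound 2 (0.31 log units; beyond the scatter), shows that swapping one aryl on this nitrogen for another shifts this assay by a modest amount. The step to compound 3 is therefore expected to be modest as well, with no direction secured. Compound 3 is expected to give 25000 nM in this assay, within 8000 nM to 80000 nM. This corresponds to an estimated step of a 1.4-fold lower number from compound 2 to compound 3 (0.14 log units; within the scatter).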

Compound 3, half-maximal inhibitory concentration: 24300 nM
For compound 3 the middle estimate is 1.0-fold (0.01 log units) above the measured one; measured number inside the range.
By their numbers in this assay, from the lowest: compounds 1, 3 and 2 (each within the scatter of the next, the first and the last beyond it).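

In this assay, the 4-ethylphenyl group cannot be told apart from either earlier group on this nitrogen: the measured changes are a 1.4-fold lower number from compound 2 to compound 3 (0.16 log units; within the scatter), and a 1.4-fold higher number from compound 1 to compound 3 (0.15 log units; within the scatter). Replacing the oxygen-bearing 3-methoxyphenyl or the bromine-bearing 2-bromophenyl with this all-carbon group therefore leaves the number within the scatter, even though those two earlier groups are separated by a 2.0-fold higher number from compound 1 to compound 2 (0.31 log units; beyond the scatter). No evidence is available to explain this result.

All three groups here are substituted phenyl rings, so the compounds shown leave open how an amine or a carboxylic acid on that ring, or a longer alkyl chain in place of ethyl, would read in this assay. They also leave open whether the place of a substituent on the ring matters apart from its identity, since the group and its place differ together here.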